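This account rests on a few compounds, and the source may have more. Where it says the series, first, only, none or still open, it means among the compounds named here.

In a functional assay on HL-60 cells (Homo sapiens) for antiproliferative activity, read by MTT assay, with a stated time of 24 h (a higher number here means a weaker inhibitor, a lower number a stronger inhibitor), compound 1 `CCCCc1oc2ccccc2c1C(=O)c1ccc(OCC(=O)NC(C)C)cc1` gives 360 nM. Compound 2 `CCCCNC(=O)COc1ccc(C(=O)c2c(CCCC)oc3ccccc23)cc1` gives > 50000 nM, which is a limit of the assay and not a number. Compound 3 `CCCCc1oc2ccccc2c1C(=O)c1ccc(OCC(=O)N2CCCCC2)cc1` carries piperidin-1-yl in place of butylamino on a carbonyl carbon. Among the measured compounds shown here, one measured step bears on this change: butyl in place of isopropyl on the amide-type nitrogen, an at least 130-fold higher number from compound 1 to compound 2 (2.14 log units; beyond the scatter), large and beyond the scatter. The amide substituent can therefore move this read-out strongly, so a large step to a lower number in this assay is expected, an at least 12-fold lower number from compound 2 to compound 3 (1.09 log units; beyond the scatter). For compound 3 the estimated value is 4000 nM, with an expected range of 400 nM to 50000 nM.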

Compound 3, half-maximal inhibitory concentration: > 50000 nM
Compound 3 gave a limit, no number; the forecaster's own chance of this, stated with the estimate: 35%; middle value at least 12-fold (1.09 log units) from the limit.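

In this assay, piperidin-1-yl in place of isopropylamino on a carbonyl carbon gives an at least 130-fold higher number from compound 1 to compound 3 (2.14 log units; beyond the scatter). The earlier pair showed this only for an open butyl chain; a ring without the amide hydrogen now ends at a limit too, leaving isopropylamino as the only group shown here with a number. The step between compound 2 and compound 3 cannot be read, as both values are limits of the assay and not numbers: the limit of > 50000 nM in this assay, at which 2 of the 3 values shown sit.

From the compounds shown here alone, whether ethylamino, pyrrolidin-1-yl or morpholin-4-yl at this carbonyl carbon gives a number rather than a limit stays open.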